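Trading trifluoromethyl for amino on a weak compound

The source may report more compounds than this note shows. Statements on the series, on what has been measured and on what is new or still open speak of the compounds shown alone.

In a functional assay on MGC-803 cells (Homo sapiens) for antiproliferative activity, read by MTT assay, with a stated time of 48 h (a lower number here means a stronger inhibitor, a higher number a weaker inhibitor), compound 1 (`COc1ccc(CN(C(=O)CSc2nc3ccccc3s2)c2cc(OC)c(OC)c(OC)c2)cc1N=[N+]=[N-]`) gives 187 nM and compound 3 (`COc1ccc(CN(C(=O)CSc2nc3ccccc3s2)c2cc(OC)c(OC)c(OC)c2)cc1C(F)(F)F`) gives 25200 nM, the higher of these two numbers. Compound 2 (`COc1cc(N(Cc2ccc(F)cc2)C(=O)CSc2nc3ccccc3s2)cc(OC)c1OC`) reaches only a limit of the assay, > 80000 nM. Compound 4 (`COc1ccc(CN(C(=O)CSc2nc3ccccc3s2)c2cc(OC)c(OC)c(OC)c2)cc1N`) carries amino in place of the trifluoromethyl of compound 3: amino in place of trifluoromethyl on an aromatic carbon. The nearest evidence is the swap at that same carbon, trifluoromethyl in place of azido, which gave a 130-fold higher number from compound 1 to compound 3 (2.13 log units; beyond the scatter). Replacing the whole 3-azido-4-methoxyphenyl with 4-fluorophenyl gave an at least 420-fold higher number from compound 1 to compound 2 (2.63 log units; beyond the scatter). Compound 1 thus shows how much this carbon can matter, so removing the trifluoromethyl should help, although amino is not azido. The expected change is a 36-fold lower number from compound 3 to compound 4 (1.56 log units; beyond the scatter), a large step towards a lower number. Compound 4 is estimated at 700 nM, with an expected range from 90 nM to 6000 nM.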

Compound 4, half-maximal inhibitory concentration: 84 nM
The estimate for compound 4 lay 8.3-fold (0.92 log units) above the measured number; the measured number lies below the stated range.
By their numbers in this assay, from the lowest: compound 4; then compound 1; then compound 3. At a limit, above all of these: compound 2.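

Amino at this carbon gives a 300-fold lower number from compound 3 to compound 4 (2.48 log units; beyond the scatter), so a low number here does not depend on azido alone. Compared directly with azido, amino gives a 2.2-fold lower number from compound 1 to compound 4 (0.35 log units; beyond the scatter), a modest step that is still beyond the usual scatter. With 3-amino-4-methoxyphenyl in place of 4-fluorophenyl the step is an at least 950-fold lower number from compound 2 to compound 4 (2.97 log units; beyond the scatter), but compound 2 marks a limit of the assay, not a number: the limit of > 80000 nM in this assay, at which 1 of the 4 values shown sits.

On these data alone, whether a hydroxyl or a methylamino group at this carbon would keep the number this low stays open. So does whether amino needs the methoxy group of the 3-amino-4-methoxyphenyl.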